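Swapping the aryl hydrazone in a triazolylpyridine urea series

The compounds below may be only part of what the source reports. "The series", "measured", "known", "first", "only" and "open" are said of these compounds alone.

Measured so far:
compound 1 `CN(C)CCn1cnnc1-c1cc(Oc2ccc(NC(=O)N/N=C/c3ccc(F)cc3F)cc2F)ccn1` — 1870 nM
compound 2 `CN(C)CCn1cnnc1-c1cc(Oc2ccc(NC(=O)N/N=C/c3cccc(Cl)c3Cl)cc2F)ccn1` — 1090 nM

In a functional assay on A549 cells (Homo sapiens) for cytotoxicity, read by MTT assay, with a stated time of 72 h (on this read-out higher numbers stand for weaker inhibition and lower numbers for stronger inhibition), compound 1 gives 1870 nM and compound 2 gives 1090 nM. The only step shown, a 1.7-fold lower number from compound 1 to compound 2 (0.23 log units; within the scatter), leaves the two values within the scatter of each other, so compound 2 cannot be called stronger than compound 1. Compound 3 `CN(C)CCn1cnnc1-c1cc(Oc2ccc(NC(=O)N/N=C/c3ccc(O)cc3)cc2F)ccn1` carries 4-hydroxyphenyl in place of 2,3-dichlorophenyl on a carbon with a double bond to nitrogen. Among the measured compounds shown here, no measured step involves a hydroxyphenyl group, so the single within-scatter step offers no grounds to expect a change beyond the scatter. Compound 3 is therefore estimated at 1500 nM, a step of a 1.4-fold higher number from compound 2 to compound 3 (0.14 log units; within the scatter), with a range from 500 nM to 5000 nM.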

Compound 3, half-maximal inhibitory concentration: 3560 nM
For compound 3 the middle estimate is 2.4-fold (0.38 log units) below the measured one; measured number inside the range.
By their numbers in this assay, from the lowest: compounds 2, 1 and 3 (each within the scatter of the next, the first and the last beyond it).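

In this assay the aryl group on a carbon with a double bond to nitrogen now proves able to shift the number beyond the scatter: 4-hydroxyphenyl in place of 2,3-dichlorophenyl gives a 3.3-fold higher number from compound 2 to compound 3 (0.51 log units; beyond the scatter) while 4-hydroxyphenyl in place of 2,4-difluorophenyl gives a 1.9-fold higher number from compound 1 to compound 3 (0.28 log units; within the scatter) and stays within it. So the same entering group registers against one leaving group and not the other. Nothing available explains this. The compounds shown leave open whether the hydroxyl or the loss of the chlorines drives the larger step, and whether a 4-methoxyphenyl or 4-aminophenyl group would behave like 4-hydroxyphenyl.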